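Extending the methylsulfanyl group of compound 2

The compounds below may be only part of what the source reports. "The series", "measured", "known", "first", "only" and "open" are said of these compounds alone.

compound 1 `CCn1cc(-c2ccnc(Nc3ccc(OC)cc3OC)n2)c2ccccc21`: 3590 nM
compound 2 `COc1ccc(Nc2nccc(-c3sc(SC)nc3C)n2)c(OC)c1`: 530 nM

In a functional assay on MV4-11 cells (Homo sapiens) for inhibition, read by resazurin assay, with a stated time of 72 h (a lower number here means a stronger inhibitor of growth, a higher number a weaker inhibitor of growth), compound 2 gives 530 nM as the lower of the two numbers, and the gap up to compound 1 lies beyond the scatter. Compound 3 `COc1ccc(Nc2nccc(-c3sc(SCc4cccnc4)nc3C)n2)c(OC)c1` is not yet measured. It differs from compound 2 by pyridin-3-yl in place of hydrogen on a saturated chain carbon bound to a sulfur and carries pyridin-3-yl in place of hydrogen on a saturated chain carbon bound to a sulfur, so methylsulfanyl becomes ((pyridin-3-yl)methyl)sulfanyl. Among the measured compounds shown here, no measured pair differs in one place only, so the data give no direct guide to this change. The expected result is no change beyond the scatter, although a move either way remains possible. The estimated 1.3-fold lower number from compound 2 to compound 3 (0.12 log units; within the scatter) is therefore expected to be small. For compound 3 the estimate is 400 nM in this assay, with an expected range from 100 nM to 1500 nM.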

Compound 3, concentration for 50% growth inhibition: 270 nM
Estimate against measurement, compound 3: 1.5-fold (0.17 log units) above, within the range that was stated.
By their numbers in this assay, from the lowest: compounds 3 and 2 (each within the scatter of the next); then compound 1.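

In this assay, the first step measured at this position reads a 2.0-fold lower number from compound 2 to compound 3 (0.29 log units; within the scatter). This shows that a saturated chain carbon bound to a sulfur can carry pyridin-3-yl, a six-membered aromatic ring of 6 heavy atoms, in place of hydrogen with no loss of growth inhibition beyond the scatter, although no gain can be claimed either. No available measurement explains this result.

From the compounds shown here alone, it remains open whether the nitrogen of the ring matters, which a comparison with benzylsulfanyl, carrying a plain phenyl ring, would test directly. Also open, going by these compounds, is how the number responds to other groups on the sulfur, such as a longer chain like 2-(pyridin-3-yl)ethyl or an amine such as 2-(dimethylamino)ethyl.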